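This account rests on a few compounds, and the source may have more. Where it says the series, first, only, none or still open, it means among the compounds named here.

Compounds measured so far:
Compound 1 `O=C(/C=C/c1cccnc1)NCCCc1cccc(S(=O)(=O)Nc2ccccc2)c1`: 165 nM
Compound 2 `Cc1ccc(NS(=O)(=O)c2cccc(CCCCCCNC(=O)/C=C/c3cccnc3)c2)cc1`: 34.4 nM
Compound 3 `Cc1cccc(NS(=O)(=O)c2cccc(CCCCCCNC(=O)/C=C/c3cccnc3)c2)c1`: 41.7 nM

In a functional assay on DU-145 cells (Homo sapiens) for inhibition, read by CCK-8 assay, with a stated time of 72 h (on this read-out lower numbers stand for stronger inhibition and higher numbers for weaker inhibition), compound 3 gives 41.7 nM. This cannot be told apart from compound 2 at 34.4 nM. Compound 1 gives 165 nM, and the scatter does not cover its gap to compound 3, which stands on the side of weaker inhibition for compound 1. Compound 4 `CCc1ccc(NS(=O)(=O)c2cccc(CCCCCCNC(=O)/C=C/c3cccnc3)c2)cc1` carries 4-ethylphenyl in place of 3-methylphenyl on a sulfonamide nitrogen. Among the measured compounds shown here, the one measured step that bears on this change is a 1.2-fold higher number from compound 2 to compound 3 (0.08 log units; within the scatter), which swaps 4-methylphenyl for 3-methylphenyl at the same place and stays within the scatter. For the measured compounds named here, no measured compound yet carries the ethyl group, so the expectation in this assay is for no change beyond the scatter. The expected step is a 1.1-fold lower number from compound 3 to compound 4 (0.04 log units; within the scatter). Compound 4 is estimated at 38 nM, with an expected range of 17 nM to 85 nM.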

Compound 4, half-maximal inhibitory concentration: 40.1 nM
Beside the measured number, compound 4's estimate is 1.1-fold (0.02 log units) below it, and the stated range covers the measured number.
By their numbers in this assay, from the lowest: compounds 2, 4 and 3 (each within the scatter of the next); then compound 1.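

In this assay, the sulfonamide nitrogen tolerates 4-ethylphenyl: replacing 3-methylphenyl gives a 1.0-fold lower number from compound 3 to compound 4 (0.02 log units; within the scatter), and methyl in place of hydrogen on the saturated chain carbon bound to an aromatic carbon gives a 1.2-fold higher number from compound 2 to compound 4 (0.07 log units; within the scatter). This extends the flat picture from methyl placement to a longer alkyl group on the phenyl. Nothing available explains why these changes leave the number within the scatter. Still open, on these data alone, is whether a methoxy, a trifluoromethyl, a carboxylic acid or a tert-butyl on this phenyl would shift the number beyond the scatter.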